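A Dihydroxyphenyl Group Replaces a Methoxyphenyl Group

The source may report more compounds than this note shows. Statements on the series, on what has been measured and on what is new or still open speak of the compounds shown alone.

In a functional assay on MDA-MB-231 cells (Homo sapiens) for inhibition, read by MTT assay, with a stated time of 48 h (a higher number here means a weaker inhibitor, a lower number a stronger inhibitor), compound 3 `COc1ccc(-c2cc(-c3cc(OC)c(OC)c(OC)c3)nc(-c3ccccc3)n2)cc1` gives 3390 nM and compound 2 `COc1cc(-c2cc(-c3ccc(C)cc3)nc(-c3ccccc3)n2)cc(OC)c1OC` gives 5110 nM; the two sit within the scatter of each other, with a 1.5-fold lower number from compound 2 to compound 3 (0.18 log units; within the scatter). Compound 1 `COc1cc(-c2cc(-c3ccc(Br)cc3)nc(-c3ccccc3)n2)cc(OC)c1OC` reaches only a limit of the assay, > 25000 nM. Leaving its bromo group gave modest steps: an at least 4.8-fold lower number from compound 1 to compound 2 (0.68 log units; beyond the scatter), and an at least 7.3-fold lower number from compound 1 to compound 3 (0.86 log units; beyond the scatter). Compound 4 `COc1cc(-c2cc(-c3ccc(O)cc3O)nc(-c3ccccc3)n2)cc(OC)c1OC` instead has 2,4-dihydroxyphenyl in place of 4-methoxyphenyl on an aromatic carbon. Within the data shown here, no measured step adds a hydroxy group, so the closest guide is the small change seen in a 1.5-fold lower number from compound 2 to compound 3 (0.18 log units; within the scatter). The step expected in this assay is a 1.2-fold lower number from compound 3 to compound 4 (0.08 log units; within the scatter), which is no clear change. Compound 4 is estimated at 2800 nM, with an expected range from 700 nM to 12000 nM.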

Compound 4, half-maximal inhibitory concentration: 810 nM
Compound 4: the middle estimate sits 3.5-fold (0.54 log units) above what was measured, within the range that was stated.
By their numbers in this assay, from the lowest: compound 4; then compounds 3 and 2 (each within the scatter of the next). At a limit, above all of these: compound 1.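

At this place on the shared core, swaps among methyl and methoxy left the numbers within the scatter of each other, whereas 2,4-dihydroxyphenyl moves the number beyond it: a 4.2-fold lower number from compound 3 to compound 4 (0.62 log units; beyond the scatter), and a 6.3-fold lower number from compound 2 to compound 4 (0.80 log units; beyond the scatter). Compound 1 stands at a limit of the assay, so an at least 30-fold lower number from compound 1 to compound 4 (1.48 log units; beyond the scatter) gives a bound and not an exact size: the limit of > 25000 nM in this assay, at which 1 of the 4 values shown sits.

Both hydroxy groups enter together, and the compounds shown do not tell which one carries the step. As far as these compounds go, how an amine or a carboxylic acid on this phenyl ring would read also stays open.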